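Trifluoromethylphenyl position on the shared pyridine-free core: notes

The source may report more compounds than this note shows. Statements on the series, on what has been measured and on what is new or still open speak of the compounds shown alone.

Measured compounds in a functional assay on T47D cells (Homo sapiens) for inhibition; on this read-out higher numbers stand for weaker inhibition and lower numbers for stronger inhibition:
compound 1 `Oc1ccc(-c2cc(-c3cccc(F)c3)cc(-c3cccc(O)c3)n2)cc1` gives 3510 nM
compound 2 `Oc1cccc(-c2cc(-c3cccc(C(F)(F)F)c3)cc(-c3cccc(O)c3)n2)c1` gives 4970 nM
compound 3 `Oc1ccc(-c2cc(-c3ccccc3C(F)(F)F)cc(-c3cccc(O)c3)n2)cc1` gives 3210 nM

All three numbers sit close together. Within the data shown here, compound 3 stands at 3210 nM in this assay, and the gaps to compound 1 and to compound 2 both fall within the usual scatter, so no compound can be set apart from the others on these data.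

Compound 4 `Oc1ccc(-c2cc(-c3cccc(C(F)(F)F)c3)cc(-c3cccc(O)c3)n2)cc1` is not yet measured. It differs from compound 3 in one place: 3-(trifluoromethyl)phenyl in place of 2-(trifluoromethyl)phenyl on an aromatic carbon. Among the measured compounds shown here, the only measured step that touches this position is a 1.1-fold lower number from compound 1 to compound 3 (0.04 log units; within the scatter), which did not move the number beyond the scatter. Compound 4 carries a 4-hydroxyphenyl group where compound 2 carries a 3-hydroxyphenyl group beside the same 3-(trifluoromethyl)phenyl group, and compound 2 gives 4970 nM. For the measured compounds named here, no single-change step links compound 2 to compound 4, so that value can only be taken as a rough neighbour.

Taken together, the step from compound 3 to compound 4 is expected to be a 1.2-fold higher number from compound 3 to compound 4 (0.07 log units; within the scatter), that is, no change beyond the scatter. Compound 4 is therefore estimated at 3800 nM, with a range from 1900 nM to 7600 nM in this assay.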

Compound 4, half-maximal inhibitory concentration: 2630 nM
Beside the measured number, compound 4's estimate is 1.4-fold (0.16 log units) above it, and the stated range covers the measured number.
By their numbers in this assay, from the lowest: compounds 4, 3, 1 and 2 (each within the scatter of the next).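

In this assay, 3-(trifluoromethyl)phenyl in place of 2-(trifluoromethyl)phenyl on the aromatic carbon opposite the ring nitrogen gives a 1.2-fold lower number from compound 3 to compound 4 (0.09 log units; within the scatter) and so leaves the number unchanged beyond the scatter. The two other single-change steps to the new compound read the same way, with trifluoromethyl in place of fluoro giving a 1.3-fold lower number from compound 1 to compound 4 (0.13 log units; within the scatter) and 4-hydroxyphenyl in place of 3-hydroxyphenyl giving a 1.9-fold lower number from compound 2 to compound 4 (0.28 log units; within the scatter) so that none of these changes separates compound 4 from its neighbours. No evidence on the origin of these small steps is available.

The compounds shown carry only fluoro or trifluoromethyl on this phenyl group, all at similar numbers. From the compounds shown here alone, whether an amine or a carboxylic acid on that ring, or a longer chain in its place, would move the number beyond the scatter remains open.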